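The source may report more compounds than this note shows. Statements on the series, on what has been measured and on what is new or still open speak of the compounds shown alone.

In a functional assay on CT26 cells (Mus musculus) for antiproliferative activity, read by CCK-8 assay, with a stated time of 72 h (a higher number here means a weaker inhibitor of growth, a lower number a stronger inhibitor of growth), compound 1 (`Nc1nc(NCc2ccc(C(=O)NO)cc2)nc2nc(-c3ccco3)nn12`) offers no number to start from, standing only as ("not determined" (no result reported)). Compound 2 (`Nc1nc(NCCCc2ccc(C(=O)NO)cc2)nc2nc(-c3ccco3)nn12`) reads > 100000 nM and this is a limit of the assay, not a number. Compound 3 (`Nc1nc(NCCCCCCC(=O)NO)nc2nc(-c3ccco3)nn12`) gives (31600 nM). Compound 4 (`Nc1ccccc1NC(=O)c1ccc(CNc2nc(N)n3nc(-c4ccco4)nc3n2)cc1`) has not yet been measured. The change from compound 1 is 2-aminophenyl in place of hydroxy on an amide-type nitrogen with 2-aminophenyl in place of hydroxy on an amide-type nitrogen. Among the compounds with values here, with no measured step to go on, no direction can be read from compound 1, and in this assay compound 4 is expected to stay near compound 3 (31600 nM). For compound 4 the estimated value is 20000 nM with an expected range from 3000 nM to 100000 nM in this measurement.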

Compound 4, concentration for 50% growth inhibition: 16500 nM
Compound 4: the middle estimate sits 1.2-fold (0.08 log units) above what was measured; measured number inside the range.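

No step can be read from compound 1 to compound 4 in this assay, and nothing shown bears on the value of compound 4. The compounds shown leave open how (2-aminophenyl)carbamoyl compares with hydroxycarbamoyl on the shared core.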